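Exchanging 4-fluorophenyl for 3,4-dimethoxyphenyl on compound 3

A few compounds are considered here, and "the series" means these few. Any claim that something is new, unique, unknown or untested is made for them only; others in the source may bear on it.

In a functional assay on SiHa cells (Homo sapiens) for inhibition, read by sulforhodamine B assay (on this read-out lower numbers stand for stronger inhibition of growth and higher numbers for weaker inhibition of growth), compound 1 (`Fc1ccc(-c2ccc(-c3ccc(-c4nc5ccccc5[nH]4)cc3)cc2)cc1`) gives 29700 nM and compound 2 (`COc1ccc(-c2ccc(-c3ccc(-c4nc5ccccc5[nH]4)cc3)cc2)cc1`) gives 2760 nM while compound 3 (`Oc1cccc2[nH]c(-c3ccc(-c4ccc(-c5ccc(F)cc5)cc4)cc3)nc12`) gives 9100 nM in the middle of the three numbers, with both gaps beyond the scatter. Compound 4 (`COc1ccc(-c2ccc(-c3ccc(-c4nc5c(O)cccc5[nH]4)cc3)cc2)cc1OC`) keeps the hydroxy of compound 3 and has 3,4-dimethoxyphenyl in place of 4-fluorophenyl on an aromatic carbon. Within the data shown here, the closest precedent, an 11-fold lower number from compound 1 to compound 2 (1.03 log units; beyond the scatter) for methoxy in place of fluoro, is large but comes from a core without the hydroxy. The other measured step, a 3.3-fold lower number from compound 1 to compound 3 (0.51 log units; beyond the scatter) for hydroxy in place of hydrogen, is modest and does not recur here since that hydroxy stays in place. Among the measured compounds shown here, no measured compound carries the 3,4-dimethoxyphenyl group, so the precedent is only partial. The estimate is a 6.1-fold lower number from compound 3 to compound 4 (0.78 log units; beyond the scatter) in the same direction as that precedent, though expected to be somewhat smaller. Compound 4 is estimated at 1500 nM with an expected range from 400 nM to 5500 nM in this assay once tested.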

Compound 4, concentration for 50% growth inhibition: 1110 nM
Compound 4: middle estimate off by 1.4-fold (0.13 log units), on the high side; the measured number falls inside the stated range.
By their numbers in this assay, from the lowest: compound 4; then compound 2; then compound 3; then compound 1.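

In this assay, the position para to a large group still responds to exchange when the hydroxy of compound 3 is present, with an 8.2-fold lower number from compound 3 to compound 4 (0.91 log units; beyond the scatter) for 3,4-dimethoxyphenyl in place of 4-fluorophenyl. A lower number on moving from a fluorinated ring to a methoxylated one was previously seen only without the hydroxy, as an 11-fold lower number from compound 1 to compound 2 (1.03 log units; beyond the scatter) shows, and it now appears on the hydroxy-bearing core as well, although the two exchanges are not identical. Nothing available accounts for the size of either step.

From the compounds shown here alone, how much of the new step belongs to each of the two methoxy groups remains open. Also open, going by these compounds, is whether a lower number would persist with an amine or a carboxylic acid on that ring.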